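The source may hold more compounds than are shown below. What is called first, only, known or untested is meant among the compounds shown, and "the series" means these compounds.

Measured so far in an ADME assay on S9 fraction from liver (Rattus norvegicus) for metabolic stability, read by LC-MS, using NADPH, with a stated time of 30 min; on this read-out higher numbers stand for a more stable compound and lower numbers for a less stable compound:
Compound 1 `CCCCCCCCc1ccc(OCC(=O)Cn2nnc(-c3ccc(C(=O)OC)cc3)n2)cc1`: 64%
Compound 2 `CCCCCCCCc1ccc(OCC(=O)Cn2nnc(-c3ccncc3)n2)cc1`: < 5%, a limit of the assay
Compound 3 `CCCCCCCCc1ccc(OCC(=O)Cn2nnc(-c3cccnc3)n2)cc1`: 12%

Compound 3 gives 12%, the lower of the two actual numbers, and the step separating it from the other is a number 52 percentage points lower from compound 1 to compound 3 (beyond the scatter). Compound 2 reports only a limit. Between the two pyridinyl compounds, the step is a number at least 7 percentage points higher from compound 2 to compound 3 (that floor lies within the scatter).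

Compound 4 `CCCCCCCCc1ccc(OCC(=O)Cn2nnc(C(=O)O)n2)cc1` has carboxy in place of pyridin-3-yl on an aromatic carbon. For the measured compounds named here, no measured step makes this exchange. The closest evidence comes from the same place on the shared core, where the changes were large: a number at least 59 percentage points lower from compound 1 to compound 2 (beyond the scatter), and a number 52 percentage points lower from compound 1 to compound 3 (beyond the scatter). The carboxy group holds a carbonyl, as does the 4-(methoxycarbonyl)phenyl group of compound 1 at 64%, so a sizeable rise is expected, though with much uncertainty. The expected change is a number 28 percentage points higher from compound 3 to compound 4 (beyond the scatter). For compound 4, the estimate is 40%, with an expected range from 12% to 75%.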

Compound 4, percent of the compound remaining: 52%
Compound 4: middle estimate off by 12 percentage points, on the low side, within the range that was stated.
By their numbers in this assay, from the lowest: compound 3; then compound 4; then compound 1. At a limit, below all of these: compound 2.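

Compound 4 shows that this position, on an aromatic carbon of a five-membered aromatic ring with 4 nitrogen, needs no ring at all for a high reading in this assay: carboxy, with no ring, gives a number 40 percentage points higher from compound 3 to compound 4 (beyond the scatter) and a number at least 47 percentage points higher from compound 2 to compound 4 (beyond the scatter). The second of these steps is only a floor, and compound 2 stands at a limit of the assay, not at a number: the limit of < 5% in this assay, at which 1 of the 4 values shown sits. Carboxy still falls short of the 4-(methoxycarbonyl)phenyl group, with a number 12 percentage points lower from compound 1 to compound 4 (beyond the scatter), so the highest reading stays with the larger group.

From the compounds shown here alone, it remains open whether a primary amide, a methyl ester or a plain phenyl group at this position would read closer to compound 4 or to compound 1. Going by these compounds, it is equally open whether the rise with carboxy would hold if the octyl chain gave way to a shorter chain.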